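The compounds below may be only part of what the source reports. "The series", "measured", "known", "first", "only" and "open" are said of these compounds alone.

Measured so far:
compound 1 `O=C(/C(=C\c1ccccc1OCc1ccccc1)S(=O)(=O)Cc1ccc(Cl)cc1)c1ccc(Br)cc1` — 10000 nM
compound 2 `Cc1ccc(CS/C(=C/c2ccc(O)c(O)c2O)C(=O)c2ccc(Cl)cc2)cc1` — 50000 nM
compound 3 `Cc1ccsc1/C=C(/SCc1ccc(Cl)cc1)C(=O)c1ccc([N+](=O)[O-])cc1` — a limit, see below

In a functional assay on DU-145 cells (Homo sapiens) for inhibition, read by trypan blue exclusion, with a stated time of 96 h (on this read-out lower numbers stand for stronger inhibition of growth and higher numbers for weaker inhibition of growth), compound 2 gives 50000 nM, the highest of the two numbers shown. Compound 1 gives 10000 nM, the nearest number, lower by a margin beyond the scatter. Compound 3 gives > 100000 nM, which is a limit of this assay and not a number. One of the three values sits at the limit of > 100000 nM in this assay, at which 1 of the 3 values shown sits.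

Compound 4 `Cc1ccc(CS/C(=C/c2ccccc2Br)C(=O)c2ccc(Cl)cc2)cc1` differs from compound 2 by 2-bromophenyl in place of 2,3,4-trihydroxyphenyl on a double-bonded chain carbon bound to a double-bonded chain carbon. For the measured compounds named here, no pair differing in one place has been measured, so no step size is known. A modest move toward a lower number in this assay is expected, not clearly beyond the scatter. Compound 4 is estimated at 30000 nM, range 6000 nM to 100000 nM, meaning an expected step of a 1.7-fold lower number from compound 2 to compound 4 (0.22 log units; within the scatter).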

Compound 4, concentration for 50% growth inhibition: 10000 nM
For compound 4 the middle estimate is 3.0-fold (0.48 log units) above the measured one, and the stated range covers the measured number.
By their numbers in this assay, from the lowest: compounds 1 and 4 (each within the scatter of the next); then compound 2. At a limit, above all of these: compound 3.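

For the compounds shown here, the first one-place pair gives a 5.0-fold lower number from compound 2 to compound 4 (0.70 log units; beyond the scatter) with 2-bromophenyl in place of 2,3,4-trihydroxyphenyl on a double-bonded chain carbon bound to a double-bonded chain carbon. At this position, growth inhibition therefore does not depend on the 3 hydrogen-bond donors of the leaving group, and the entering group, with 0 donors, gives the lower number. No measurement shown accounts for the size of this step.

A single pair leaves open whether the step reflects the loss of hydroxyl groups or the arrival of bromine. Also open, as far as these compounds go, is how a phenyl group bearing an amine or a carboxylic acid would read at this position.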